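Taking the fluoro away from compound 3

A few compounds are considered here, and "the series" means these few. Any claim that something is new, unique, unknown or untested is made for them only; others in the source may bear on it.

In a functional assay on MCF7 cells (Homo sapiens) for cytotoxicity, read by MTT assay, with a stated time of 72 h (a lower number here means a stronger inhibitor, a higher number a weaker inhibitor), compound 1 `CCc1ccc(-c2cc(C(=O)Nc3ccc(Oc4ccnc(C(=O)NC)c4)cc3)ncn2)cc1` gives 6350 nM and compound 2 `CNC(=O)c1cc(Oc2ccc(NC(=O)c3cc(-c4ccccc4)ncn3)cc2)ccn1` gives 18200 nM. The step between them is a 2.9-fold higher number from compound 1 to compound 2 (0.46 log units; beyond the scatter), with hydrogen in place of ethyl on an aromatic carbon. Compound 3 `CNC(=O)c1cc(Oc2ccc(NC(=O)c3cc(-c4ccc(F)cc4)ncn3)cc2F)ccn1` stands at > 100000 nM, which is a limit of the assay and not a number. Compound 4 `CNC(=O)c1cc(Oc2ccc(NC(=O)c3cc(-c4ccc(F)cc4)ncn3)cc2)ccn1` differs from it by hydrogen in place of fluoro on an aromatic carbon, ortho to a (2-(methylcarbamoyl)pyridin-4-yl)oxy group (hydrogen in place of fluoro on an aromatic carbon). Within the data shown here, no measured step makes this exact change, and the one measured step was modest and concerns ethyl. Compound 2 also lacks this fluoro and reads 18200 nM, so a large step to a lower number is expected in this assay. The estimated change is an at least 6.6-fold lower number from compound 3 to compound 4 (0.82 log units; beyond the scatter). For compound 4 the estimated value is 15000 nM, with an expected range of 4000 nM to 60000 nM.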

Compound 4, half-maximal inhibitory concentration: > 100000 nM
Compound 4 gave a limit, no number; the forecaster's own chance of this, stated with the estimate: 12%; at least 6.6-fold (0.82 log units) between middle value and limit.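

In this assay, compound 4 stays at a limit of the assay, as compound 3 does, so the step between them cannot be read and taking this fluoro away brings no measurable gain: the limit of > 100000 nM in this assay, at which 2 of the 4 values shown sit.

The readable change lies elsewhere, at the aromatic carbon that carries ethyl in compound 1, where fluoro appears as an at least 5.4-fold higher number from compound 2 to compound 4 (0.73 log units; beyond the scatter) against hydrogen and as an at least 15-fold higher number from compound 1 to compound 4 (1.19 log units; beyond the scatter) against ethyl. At that carbon, numbers rise from ethyl through hydrogen to fluoro.

From the compounds shown here alone, it remains open whether the fluoro ortho to a (2-(methylcarbamoyl)pyridin-4-yl)oxy group has any effect when the other fluoro is absent. Also open, going by these compounds, is whether a longer chain or an amine at the carbon carrying ethyl would give a lower number.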